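Shifting One Chlorine on the Anilino Ring of Compound 3

This account rests on a few compounds, and the source may have more. Where it says the series, first, only, none or still open, it means among the compounds named here.

This series shares a core carrying a methylpiperazine and an anilino substituent, and differs only in the halogens on that anilino ring. In a functional assay on CWR22R cells (Homo sapiens) for inhibition, with a stated time of 120 h, tested at 10 uM (on this read-out higher numbers stand for more inhibition at the one concentration tested (going by the name of the read-out) and lower numbers for less inhibition), compound 1 `Cc1n[nH]c2ccc(-c3nc4cnc(N5CCN(C)CC5)cn4c3Nc3ccc(I)cc3)cc12` gives "not determined" (no result reported) and compound 2 `Cc1n[nH]c2ccc(-c3nc4cnc(N5CCN(C)CC5)cn4c3Nc3ccc(Br)cc3Cl)cc12` gives "not determined" (no result reported), so neither has a result reported. Among the compounds with values here, compound 3 `Cc1n[nH]c2ccc(-c3nc4cnc(N5CCN(C)CC5)cn4c3Nc3ccc(Cl)cc3Cl)cc12` is therefore the only member with a number: in this assay compound 3 gives 9.53%, a weak read-out, and it stands alone rather than within any ordering.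

Compound 4 `Cc1n[nH]c2ccc(-c3nc4cnc(N5CCN(C)CC5)cn4c3Nc3cc(Cl)ccc3Cl)cc12` is a rearrangement of compound 3 with the same atoms joined differently (2,5-dichlorophenyl in place of 2,4-dichlorophenyl on a nitrogen on an aromatic ring). Within the data shown here, no step between measured compounds is available to guide how such a change plays out here, so the expectation rests on compound 3 alone. Because compound 3 gives 9.53%, compound 4 is expected to stay close, with a step from compound 3 of a number 0.5 percentage points higher from compound 3 to compound 4 (within the scatter) that should lie within the usual scatter. The estimate for compound 4 in this assay is 10%, with a range from -8% to 30%.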

Compound 4, a percentage reported as inhibition, at one concentration (the size of the read-out at that concentration, not a potency): 3.8%
For compound 4 the middle estimate is 6.2 percentage points above the measured one; low and high end bracket the measured number.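

The swap of 2,4-dichlorophenyl for 2,5-dichlorophenyl on a nitrogen on an aromatic ring gives the series its first readable step in this assay, a number 5.7 percentage points lower from compound 3 to compound 4 (within the scatter). Compound 3 and compound 4 therefore cannot be told apart in this read-out, so relocating one chlorine on this ring, with the same atoms throughout, has no effect that this assay can resolve. No measurement is available that bears on this result.

What the compounds shown leave open is how this position responds to a group other than a halogen, such as an amine, a carboxylic acid or a longer chain in place of a chlorine. Steps involving compound 1 and compound 2 cannot be read, so the iodine and bromine variants add nothing to the comparison.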